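Branching the Side Chain of a Cyanoguanidine Series

A few compounds are considered here, and "the series" means these few. Any claim that something is new, unique, unknown or untested is made for them only; others in the source may bear on it.

Of the compounds shown here, three sharing one core have been tested in a functional assay on the whole organism (blood, strain Wistar-Okamoto) with Rattus norvegicus as the target, with a stated time of 5 days; a lower number here means that less compound is needed, a higher number that more compound is needed for the effect. Compound 1 `CC(C)CC/N=C(\NC#N)Nc1cccnc1` carries an isopentyl group on the double-bonded nitrogen and gives 20 mg/kg in this assay, the highest number among the three measured compounds. Compound 2 `CC(/N=C(/NC#N)Nc1cccnc1)C(C)(C)C` gives 1 mg/kg in this assay, and compound 3 `CC(C)C(/N=C(\NC#N)Nc1cccnc1)C(C)C` gives 5 mg/kg in this assay. Both of these values lie beyond the usual scatter below that of compound 1, so among these three compounds the two more branched side chains go with the lower numbers, compound 2 most clearly.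

Compound 4 `CC(C)C(C)(C)/N=C(\NC#N)Nc1cccnc1` has not yet been measured in this assay. It differs from compound 1 in one place: 1,1,2-trimethylpropyl in place of isopentyl on a double-bonded nitrogen. The new group is branched where the old one was not, which puts compound 4 closer in shape to compound 2 and compound 3 than to compound 1.

Given that compound 2 and compound 3 both need less compound than compound 1, compound 4 is expected to need less as well, a step of a 6.7-fold lower number from compound 1 to compound 4 (0.82 log units; beyond the scatter), beyond the scatter. The estimate for compound 4 is 3 mg/kg, with a likely range from 1 mg/kg to 10 mg/kg.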

Compound 4, minimum effective dose: 1 mg/kg
Estimate against measurement, compound 4: 3.0-fold (0.48 log units) above; measured number inside the range.
By their numbers in this assay, from the lowest: compounds 2 and 4 (each within the scatter of the next); then compound 3; then compound 1.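

Replacing isopentyl with 1,1,2-trimethylpropyl on a double-bonded nitrogen gives a 20-fold lower number from compound 1 to compound 4 (1.30 log units; beyond the scatter) in this assay. Within the data shown here, this is the first comparison in which only one place changes, so it ties a large shift in the dose needed directly to the group at this position, which the earlier compounds could only suggest. Among these compounds, the entering group has 6 carbon atoms against 5 in the group that leaves, neither group has a ring, and nothing available explains why this swap moves the number so far.

Going by these compounds, it remains open whether the shift follows the branching of the new group or simply its extra carbon, and an unbranched hexyl chain at this position would help to separate those two readings. On these data alone, it is also open how this position would respond to a cyclohexyl ring or to a chain ending in an amine, and whether such groups would keep the low dose needed in this assay.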